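The source may hold more compounds than are shown below. What is called first, only, known or untested is meant among the compounds shown, and "the series" means these compounds.

Compound 1 `C=C1C(=O)[C@]23C[C@@]1(O)CC[C@H]2c1ccc(O)c(C)c1[C@@H]3Cn1cc(-c2ccc(C)cc2)nn1` and compound 3 `C=C1C(=O)[C@]23C[C@@]1(O)CC[C@H]2c1ccc(O)c(C)c1[C@@H]3Cn1cc(-c2ccc(OC)cc2)nn1` share one core, while compound 2 `Cc1ccc(-c2cn(C[C@H]3c4c(ccc(O)c4C)[C@@H]4CC[C@@]5(C)C[C@]43CC5=O)nn2)cc1` and compound 4 `COc1ccc(-c2cn(C[C@H]3c4c(ccc(O)c4C)[C@@H]4CC[C@@]5(C)C[C@]43CC5=O)nn2)cc1` share another; the difference between the two cores is not broken down here. In a functional assay on SMMC-7721 cells (Homo sapiens) for cytotoxicity, read by MTT assay, with a stated time of 4 days (on this read-out lower numbers stand for stronger inhibition and higher numbers for weaker inhibition), compound 1 gives 920 nM. In this assay compound 3 gives 860 nM. The change from compound 1 to compound 3 is methoxy in place of methyl on an aromatic carbon and it made a 1.1-fold lower number from compound 1 to compound 3 (0.03 log units; within the scatter), so the two values sit within the usual scatter of each other. In this assay compound 2 is reported only as a limit, > 20000 nM. That limit is the limit of > 20000 nM in this assay, at which 1 of the 3 values shown sits. Compound 4 differs from compound 2 by the same change, (methoxy in place of methyl on an aromatic carbon), at the same place on the ring. Because the step of a 1.1-fold lower number from compound 1 to compound 3 (0.03 log units; within the scatter) stayed within the scatter, a step that the limit leaves unreadable from compound 2 to compound 4 is expected for the same change on the second core. Compound 4 is therefore estimated to come out near 30000 nM, most likely between 8000 nM and 120000 nM, and in this assay compound 4 may well again be reported only as a limit.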

Compound 4, half-maximal inhibitory concentration: > 20000 nM
Compound 4: only a limit was reported; the forecaster's own chance of this, stated with the estimate: 80%; the middle value does not contradict the limit.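

In this assay, within the data shown here, compound 2 and compound 4 both stand only as limits, not as numbers, so the change from 4-methylphenyl to 4-methoxyphenyl on their shared core gives no step that can be read: the limit of > 20000 nM in this assay, at which 2 of the 4 values shown sit. The compounds shown leave open how far each of these two lies beyond that limit, and whether this change has any effect on that core.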